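Acetylated oxadiazoline series: removing a methoxy, two settings

The source may report more compounds than this note shows. Statements on the series, on what has been measured and on what is new or still open speak of the compounds shown alone.

The set rests on one shared core carrying an acetyl on the ring nitrogen and two aryl groups. Compound 1 `COc1ccc(C2OC(c3cc(OC)c(OC)c(OC)c3)=NN2C(C)=O)cc1` carries methoxy groups on both aryl rings and in a functional assay on L1210 cells (Mus musculus) for antiproliferative activity, read by MTT assay, with a stated time of 72 h (on this read-out higher numbers stand for weaker inhibition and lower numbers for stronger inhibition), compound 1 gives 57000 nM. Compound 2 `COc1cc(C2=NN(C(C)=O)C(c3ccccc3)O2)cc(OC)c1OC` keeps the trimethoxyphenyl and in this assay compound 2 gives 6400 nM. Compound 3 `COc1ccc(C2=NN(C(C)=O)C(c3ccccc3OC)O2)cc1` pairs a 4-methoxyphenyl with a 2-methoxyphenyl and in this assay compound 3 gives 5800 nM; its nearest neighbour is compound 2, within the scatter, while compound 1 sits well apart.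

The step of an 8.9-fold lower number from compound 1 to compound 2 (0.95 log units; beyond the scatter) rests on the change (hydrogen in place of methoxy on an aromatic carbon). Compound 4 `COc1ccc(C2=NN(C(C)=O)C(c3ccccc3)O2)cc1` is reached from compound 3 by hydrogen in place of methoxy on an aromatic carbon. The two changes are of the same kind, not the same: in compound 1 the leaving methoxy sits para to a large group, in compound 3 it sits ortho to a large group. How the cores of compound 1 and compound 3 differ is not broken down here.

Among the measured compounds shown here, on the strength of the only measured analogue, the step from compound 1 to compound 2, a lower number is expected for compound 4 in this assay, but the move across the ring leaves the size uncertain, so the expected step is a 1.7-fold lower number from compound 3 to compound 4 (0.22 log units; within the scatter). Compound 4 is expected to give 3500 nM, within 1200 nM to 12000 nM.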

Compound 4, half-maximal inhibitory concentration: > 100000 nM
Compound 4: a limit, no number; the forecaster's own chance of this, stated with the estimate: 5%; at least 28-fold (1.45 log units) between middle value and limit.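

In this assay compound 4 gives > 100000 nM, which is a limit of the assay and not a number. Hydrogen in place of methoxy on an aromatic carbon here gives an at least 17-fold higher number from compound 3 to compound 4 (1.23 log units; beyond the scatter), so the direction of this change does not carry over from one core to the other in these two settings: the same change on two cores in this assay, an 8.9-fold lower number (0.95 log units; beyond the scatter) from compound 1 to compound 2 and an at least 17-fold higher number (1.23 log units; beyond the scatter) from compound 3 to compound 4, at least 150-fold (2.18 log units) apart, beyond the scatter of two such steps This rests on one pair for each setting, and the two pairs differ both in their cores and in where the methoxy leaves, ortho to a large group in compound 3 and at a different place in compound 1, so the data neither separate these two differences nor give a rule for other compounds in the series.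

Still open, as far as these compounds go, is whether the methoxy of compound 3 can give way to a hydroxy group, a fluorine or an amine on that same aromatic carbon without a step of similar size towards weaker inhibition. Also open, from the compounds shown here alone, is whether the opposite directions of the two steps persist when the acetyl on the ring nitrogen is replaced by a longer acyl chain, such as propionyl or butyryl.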